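Purine nucleoside series: B-cell maximal response, decyl to azidohydroxypropyl

A few compounds are considered here, and "the series" means these few. Any claim that something is new, unique, unknown or untested is made for them only; others in the source may bear on it.

Measured compounds:
compound 1 `CCCCCCCCCCn1c(=O)n(C2OC(CO)[C@@H](O)[C@H]2O)c2nc(N)nc(O)c21` gives 0%
compound 2 `C=CCSc1nc2c(O)nc(N)nc2n1C1OC(CO)[C@@H](O)[C@H]1O` gives 107%

In a functional assay on the whole organism (B cells) with Mus musculus as the target (on this read-out lower numbers stand for smaller maximal responses and higher numbers for larger maximal responses), compound 1 gives 0%, the lower of the two values shown, and compound 2 gives 107%. Among the compounds with values here, the gap between the two lies beyond the scatter of the method, but the two structures differ in more than one place, so no one-place step among the measured compounds is available.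

Compound 3 `[N-]=[N+]=NCC(O)Cn1c(=O)n(C2OC(CO)[C@@H](O)[C@H]2O)c2nc(N)nc(O)c21` has not yet been measured. It differs from compound 1 in one place: 2-azido-1-hydroxyethyl in place of nonyl on a saturated chain carbon bound to an aromatic nitrogen. The rest of compound 1, including the carbonyl on its core, is kept.

Within the data shown here, with no one-place step known, the size of the step from compound 1 to compound 3 is a guess. Compound 1 sits at the floor of the read-out, so the step can only hold or rise. A moderate rise, beyond the scatter, is expected, partly because compound 2 reaches 107% on a related core; the expected step is a number 30 percentage points higher from compound 1 to compound 3 (beyond the scatter). Compound 3 is estimated at 30%, with a range from 0% to 95%.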

Compound 3, largest response reached (reported as maximal response), in percent of the reference or control that the assay uses: 91%
For compound 3 the middle estimate is 61 percentage points below the measured one; the measured number falls inside the stated range.
By their numbers in this assay, from the lowest: compound 1; then compound 3; then compound 2.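

In this assay, within the data shown here, 2-azido-1-hydroxyethyl in place of nonyl on a saturated chain carbon bound to an aromatic nitrogen gives the first one-place step, and the response is a number 91 percentage points higher from compound 1 to compound 3 (beyond the scatter). This position is therefore not silent: with the rest of compound 1 kept, including the carbonyl on its core, the group at this place alone separates compound 1 at 0% from compound 3 at 91%, and the carbonyl-bearing core proves able to carry a large maximal response. No measurement on hand explains this step.

The change replaces a long carbon chain with a shorter one bearing both a hydroxyl and an azide, so the step cannot yet be divided among chain shortening, the hydroxyl and the azide. A plain propyl chain, a 3-hydroxypropyl group or a 3-amino-2-hydroxypropyl group at this place would each separate those parts, since each keeps some features of 3-azido-2-hydroxypropyl and drops others.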